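Removing a fluoro from a dichloroacetamide biaryl

The source may report more compounds than this note shows. Statements on the series, on what has been measured and on what is new or still open speak of the compounds shown alone.

Measured compounds:
Compound 1, `COc1ccc(-c2cc(NC(=O)C(Cl)Cl)cc(-c3ccc(OC)c(F)c3)c2)cc1F`, gives 1760 nM in a functional assay on NCI-H460 cells (Homo sapiens) for cytotoxicity, read by MTT assay, with a stated time of 68 h; a higher number here means a weaker inhibitor, a lower number a stronger inhibitor.
Compound 2, `CC(C)Oc1ccc(-c2cc(NC(=O)C(Cl)Cl)cc(-c3ccc(OC(C)C)cc3)c2)cc1`, gives 2860 nM in this assay.
Compound 3, `O=C(Nc1cccc(-c2ccccc2F)c1)C(Cl)Cl`, gives 26800 nM in this assay.

Among the three measured values in this assay, compound 3 has the highest number, that is the weakest inhibition; its nearest neighbour is compound 2, and compound 1 lies further off, both gaps beyond the scatter. Compound 4, `O=C(Nc1cccc(-c2ccccc2)c1)C(Cl)Cl`, differs from compound 3 in one place: hydrogen in place of fluoro on an aromatic carbon. Going by the values given here, no step between measured compounds isolates this change, so no measured step guides the expectation. With nothing to suggest otherwise, the step of a 1.1-fold higher number from compound 3 to compound 4 (0.05 log units; within the scatter) is expected to be small, in either direction, and not beyond the scatter. Compound 4 is therefore estimated at 30000 nM, with a range of 12000 nM to 75000 nM.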

Compound 4, half-maximal inhibitory concentration: 20200 nM
Beside the measured number, compound 4's estimate is 1.5-fold (0.17 log units) above it; the measured number falls inside the stated range.
By their numbers in this assay, from the lowest: compounds 1 and 2 (each within the scatter of the next); then compounds 4 and 3 (each within the scatter of the next).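

In this assay, hydrogen in place of fluoro on an aromatic carbon, ortho to a large group, gives a 1.3-fold lower number from compound 3 to compound 4 (0.12 log units; within the scatter) and is within the scatter. Going by these compounds alone, this is the first single change that can be read directly, and it shows that the fluoro at this place in compound 3 is not required to hold the number in this range. Nothing available explains this result and the reading goes no further than this pair. Open, going by these compounds, is whether an amine or a carboxylic acid at this place would give a step beyond the scatter. Also open, on these data alone, is whether removing the fluoro from compound 1 would read the same way.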